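Methoxy addition on a trimethoxy-free aryl series

A few compounds are considered here, and "the series" means these few. Any claim that something is new, unique, unknown or untested is made for them only; others in the source may bear on it.

Compound 1 `COc1cc(C2CC(c3ccccc3)=NN2C(=O)OCc2ccccc2)cc(OC)c1OC` sits at the assay limit in a functional assay on MDA-MB-231 cells (Homo sapiens) for antiproliferative activity, read by MTT assay, with a stated time of 48 h (a lower number here means a stronger inhibitor of growth, a higher number a weaker inhibitor of growth), giving > 10000 nM. Compound 2 `COc1ccc(C2=NN(C(=O)OCc3ccccc3)C(c3cc(OC)c(OC)c(OC)c3)C2)cc1` likewise returns only a limit, > 10000 nM, in this assay. The change between them, (methoxy in place of hydrogen on an aromatic carbon), yields a step that the two limits leave unreadable from compound 1 to compound 2; all that is shown here is the limit of > 10000 nM in this assay, at which 3 of the 3 values shown sit. Compound 3 `COC(=O)N1N=C(c2ccccc2)CC1c1ccc(OC)cc1` also sits at a limit in this assay, giving > 10000 nM. The difference between the core of compound 1 and the core of compound 3 is not broken down here.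

Compound 4 `COC(=O)N1N=C(c2ccccc2)CC1c1ccc(OC)c(OC)c1` has not been measured. It differs from compound 3 by methoxy in place of hydrogen on an aromatic carbon, the same kind of change as that from compound 1 to compound 2, though not the same: there the methoxy entered para to a large group, here it enters ortho to a methoxy group and meta to a large group. Since every value shown is a limit, the step for this kind of change cannot be read, and the estimated step from compound 3 to compound 4 is a step that the limit leaves unreadable from compound 3 to compound 4. Compound 4 is expected to give about 15000 nM in this assay, most likely reported again as a limit, with a range from 4000 nM to 60000 nM.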

Compound 4, concentration for 50% growth inhibition: 8940 nM
Estimate against measurement, compound 4: 1.7-fold (0.22 log units) above, and the stated range covers the measured number.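

In this assay, methoxy in place of hydrogen on an aromatic carbon, ortho to a methoxy group and meta to a large group, gives an at least 1.1-fold lower number from compound 3 to compound 4 (0.04 log units; that floor lies within the scatter), and compound 4 is the only compound shown with a value that is not a limit. Going by these compounds, compound 3 gives only a limit, > 10000 nM, so the true size of this step stays unknown and its printed floor lies within the scatter. Nothing here shows that the change carries from one core to another, since the step on the core of compound 1 cannot be read and the methoxy enters at a different place there: the limit of > 10000 nM in this assay, at which 3 of the 4 values shown sit.

Still open, on these data alone, is whether the step on the shared core of compound 3 and compound 4 goes beyond the scatter. Also open, as far as these compounds go, is whether an amine, a carboxylic acid or a longer chain in place of this methoxy would give a value clear of the limit.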